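The compounds below may be only part of what the source reports. "The series", "measured", "known", "first", "only" and "open" are said of these compounds alone.

Measured so far:
compound 1, `C[C@@H]1SCc2ncnc(N3CCN(C(=O)C(Cc4ccc(Cl)cc4)CN4CCCC4)CC3)c21` — in an assay on LNCaP cells for inhibition of RAC-alpha serine/threonine-protein kinase (Homo sapiens) (a higher number here means a weaker inhibitor, a lower number a stronger inhibitor), compound 1 gives 178 nM
compound 2, `CC(C)NCC(Cc1ccc(Cl)c(F)c1)C(=O)N1CCN(c2ncnc3c2[C@H](C)SC3)CC1` — in this assay compound 2 gives 92 nM

Compound 2 stands at one end of these two numbers, but its gap to compound 1 falls within the scatter of repeated measurements, so the two cannot be told apart on potency. Among the compounds with values here, compound 1 and compound 2 also differ at more than one site, so no single-change step links them and their pair says nothing about the effect of any one difference.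

Compound 3, `C[C@@H]1SCc2ncnc(N3CCN(C(=O)C(Cc4ccc(Cl)c(F)c4)CC4(N)CC4)CC3)c21`, is not yet measured in this assay. It differs from compound 2 in one place: 1-aminocyclopropyl in place of isopropylamino on a saturated chain carbon, two bonds along the chain from a carbonyl carbon. Within the data shown here, no measured pair isolates a change of this kind, so there is no precedent to lean on. The expected step is a 1.6-fold higher number from compound 2 to compound 3 (0.21 log units; within the scatter), small, toward a weaker inhibitor, and possibly not beyond the scatter. Compound 3 is therefore estimated at 150 nM, with a plausible range from 50 nM to 450 nM.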

Compound 3, half-maximal inhibitory concentration: 250 nM
The estimate for compound 3 lay 1.7-fold (0.22 log units) below the measured number, within the range that was stated.
By their numbers in this assay, from the lowest: compounds 2, 1 and 3 (each within the scatter of the next, the first and the last beyond it).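

In this assay, the series now has its first single-change step, a 2.7-fold higher number from compound 2 to compound 3 (0.43 log units; beyond the scatter), so the group on this saturated chain carbon, two bonds along the chain from a carbonyl carbon, can shift the number beyond the scatter, something the pair of compound 1 and compound 2 could not show. The change also leaves the counts of heavy atoms, hydrogen-bond donors and hydrogen-bond acceptors the same, and the only counted difference is the three-membered non-aromatic ring of carbon only in 1-aminocyclopropyl, so matching these counts was not enough to keep the number within the scatter. No measurement at hand explains the step.

This single pair cannot separate the contribution of the ring from that of the changed attachment of the nitrogen, and an open-chain 1-amino-1-methylethyl group would be the direct comparison for that question, with 1-aminocyclobutyl showing how the number reads with a larger carbon ring. As far as these compounds go, whether the step carries over to the aryl group of compound 1 also remains open.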